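A few compounds are considered here, and "the series" means these few. Any claim that something is new, unique, unknown or untested is made for them only; others in the source may bear on it.

Compound 1 `COc1ccc2cc([C@H](C)c3nnc(SCc4c(C)cc(C)cc4C)n3-c3cccc(Cl)c3)ccc2c1`: <= 400000 nM (a limit)
Compound 2 `COc1ccc2cc([C@H](C)c3n[nH]c(=S)n3-c3cccc(Cl)c3)ccc2c1`: "not determined" (no result reported)
Compound 3 `COc1ccc2cc([C@H](C)c3nnc(SCc4ccc(Cl)cc4)n3-c3ccc(Cl)cc3)ccc2c1`: 110000 nM

These three compounds were examined in a functional assay on LNCaP cells (Homo sapiens) for cytotoxicity, read by MTT assay; a higher number here means a weaker inhibitor, a lower number a stronger inhibitor. Among the compounds with values here, compound 3, at 110000 nM, holds the only actual number. Compound 1 gives <= 400000 nM, which is a limit and not a number. For compound 2 the entry reads "not determined" (no result reported), so it offers no comparison. Compound 3 therefore cannot be ranked against either of the others.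

The next compound to be tested is compound 4 `COc1ccc2cc([C@H](C)c3nnc(SCc4c(Cl)cccc4Cl)n3-c3ccc(Cl)cc3)ccc2c1`. It departs from compound 3 in one place: 2,6-dichlorophenyl in place of 4-chlorophenyl on a saturated chain carbon bound to a sulfur. In words, 2,6-dichlorophenyl stands in place of 4-chlorophenyl on a saturated chain carbon bound to a sulfur.

Within the data shown here, no pair of measured compounds shows this change or any other single change, so the series gives no measured step to scale it by. The expectation rests on compound 3 at 110000 nM alone, and it is a cautious one: no shift beyond the usual scatter in this assay, in either direction. The expected step is a 1.2-fold lower number from compound 3 to compound 4 (0.09 log units; within the scatter). For compound 4 the estimated value is 90000 nM, with an expected range of 30000 nM to 250000 nM.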

Compound 4, half-maximal inhibitory concentration: > 400000 nM
Compound 4: a limit, no number; the forecaster's own chance of this, stated with the estimate: 20%; middle value at least 4.4-fold (0.64 log units) from the limit.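

In this assay, within the data shown here, replacing 4-chlorobenzyl with 2,6-dichlorobenzyl on the sulfur gives an at least 3.6-fold higher number from compound 3 to compound 4 (0.56 log units; beyond the scatter), the first measured step and the first sign that the read-out responds to the group on this saturated chain carbon bound to a sulfur. Among these compounds, the change runs toward a weaker inhibitor, and it lies beyond the usual scatter, something the earlier compounds could not show, as none of them formed a comparable pair with a number on both sides. The entry for compound 4 is a limit of the assay and not a number, so the step has a lower bound but no full size: the limit of > 400000 nM in this assay, at which 1 of the 4 values shown sits.

Among the compounds shown here, the single step leaves open whether the shift follows from the 4-chloro substituent being lost, from the two chlorines of the 2,6-dichlorophenyl group being gained, or from both. It also leaves open how this assay would respond to an unsubstituted benzyl on the sulfur, or to a carboxylic acid or an amine on a longer chain there, with the rest of compound 3 kept the same.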